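Swapping One Group on Compound 2

The source may report more compounds than this note shows. Statements on the series, on what has been measured and on what is new or still open speak of the compounds shown alone.

Compound 1 `COc1cc(OC)c(-c2coc3cc(OCC=C(C)C)ccc3c2=O)cc1OC` gives 1090 nM
Compound 2 `COc1cc(OC)c(-c2coc3cc(OCc4ccccc4)ccc3c2=O)cc1OC` gives 2330 nM

Within the data shown here, in a functional assay on B16 cells (Mus musculus) for antiproliferative activity, read by MTT assay, with a stated time of 24 h (on this read-out higher numbers stand for weaker inhibition and lower numbers for stronger inhibition), compound 2 gives 2330 nM as the higher of the two numbers so far. Compound 3 `COc1cc(OC)c(-c2coc3cc(OCC(=O)c4cccc(C(F)(F)F)c4)ccc3c2=O)cc1OC` carries (3-(trifluoromethyl)phenyl)carbonyl in place of phenyl on a saturated chain carbon bound to an oxygen on an aromatic ring, a swap counted as (3-(trifluoromethyl)phenyl)carbonyl in place of phenyl on a saturated chain carbon bound to an oxygen on an aromatic ring in full. Among the measured compounds shown here, the only measured step at this place was modest (a 2.1-fold higher number from compound 1 to compound 2 (0.33 log units; beyond the scatter)), so in this assay no step beyond the scatter is expected, and its direction stays open. The expected step is small (a 1.2-fold lower number from compound 2 to compound 3 (0.07 log units; within the scatter)). For compound 3 the estimated value is 2000 nM with an expected range from 650 nM to 6000 nM in this read-out.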

Compound 3, half-maximal inhibitory concentration: > 10000 nM
Compound 3 ended at the assay's limit; the forecaster's own chance of this, stated with the estimate: 5%; middle value at least 5.0-fold (0.69 log units) away from the limit.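

The group on this saturated chain carbon can matter more than the earlier modest step suggested: the change gave an at least 4.2-fold higher number from compound 2 to compound 3 (0.63 log units; beyond the scatter), and against the 2-methylprop-1-en-1-yl compound it gave an at least 9.1-fold higher number from compound 1 to compound 3 (0.96 log units; beyond the scatter). Inhibition can therefore be weakened further by changing this group alone. For compound 3 the number is a limit, not a measured value: the limit of > 10000 nM in this assay, at which 1 of the 3 values shown sits.

The swap brings in a carbonyl and a trifluoromethyl together, and the compounds shown cannot separate their contributions. As far as these compounds go, whether an amine or a carboxylic acid on this chain would give stronger inhibition also stays open.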